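Ethyl in place of 4-chlorophenyl on the carbonyl carbon

This account rests on a few compounds, and the source may have more. Where it says the series, first, only, none or still open, it means among the compounds named here.

Compound 2 `O=C(Nc1cc(C(F)(F)F)cc(C(F)(F)F)c1)C1CCc2ccccc2N1C(=O)c1ccc(Cl)cc1` gives the lowest of the three measured numbers in a functional assay on HCT-15 cells (Homo sapiens) for cytotoxicity, read by sulforhodamine B assay, with a stated time of 72 h (on this read-out higher numbers stand for weaker inhibition of growth and lower numbers for stronger inhibition of growth), namely 2220 nM. Compound 1 `O=C(Nc1ccccc1C(F)(F)F)C1CCc2ccccc2N1C(=O)c1ccccc1` gives 6500 nM, and compound 3 `O=C(Nc1ccccc1C(F)(F)F)C1CCc2ccccc2N1` gives 40400 nM; these two differ in one place and the step of a 6.2-fold higher number from compound 1 to compound 3 (0.79 log units; beyond the scatter) shows that removing the benzoyl group altogether weakens growth inhibition. Compound 2 and compound 1 differ in two places, so their values are only compared as they stand. Compound 4 `CCC(=O)N1c2ccccc2CCC1C(=O)Nc1cc(C(F)(F)F)cc(C(F)(F)F)c1` differs from compound 2 by ethyl in place of 4-chlorophenyl on a carbonyl carbon. Among the measured compounds shown here, no measured pair separates an aryl acyl group from an alkyl one at this carbonyl, so the change has to be judged from the one step above: a carbonyl on the ring nitrogen is kept, so a loss smaller than that from compound 1 to compound 3 is expected, but a loss nonetheless. For compound 4 a higher number than for compound 2 is therefore expected, a 2.5-fold higher number from compound 2 to compound 4 (0.39 log units; beyond the scatter). The estimate for compound 4 is 5500 nM, with a range from 2200 nM to 15000 nM.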

Compound 4, concentration for 50% growth inhibition: 7620 nM
Compound 4: middle estimate off by 1.4-fold (0.14 log units), on the low side; measured number inside the range.
By their numbers in this assay, from the lowest: compound 2; then compounds 1 and 4 (each within the scatter of the next); then compound 3.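

In this assay, ethyl in place of 4-chlorophenyl on the carbonyl carbon gives a 3.4-fold higher number from compound 2 to compound 4 (0.54 log units; beyond the scatter) and so shows that the carbonyl alone does not hold the level of compound 2. The earlier step removed the whole benzoyl group, whereas this one keeps the carbonyl and changes only the group carried on it, so that group itself counts at this position, at least with the rest of compound 2 in place. Nothing on hand explains the size of this step.

Open, as far as these compounds go, is whether the chlorine, the aromatic ring or simply the size of the group accounts for the change; an unsubstituted phenyl, a cyclohexyl or a longer chain on the carbonyl carbon would begin to separate these. Also open, from the compounds shown here alone, is whether the same change reads alike on the amide side chain of compound 1.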